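The compounds below may be only part of what the source reports. "The series", "measured", "known", "first", "only" and "open" are said of these compounds alone.

Measured so far: compound 1 `C[Si](C)(c1ccc(OS(N)(=O)=O)cc1)c1ccc(OS(N)(=O)=O)cc1` with 81.9% and compound 2 `C[Si](C)(c1ccc(O)cc1)c1ccc(OS(N)(=O)=O)cc1` with 76.4% in an assay on MCF7 cells for inhibition of Steryl-sulfatase (Homo sapiens), read by scintillation counting, with a stated time of 5 h, tested at 1 uM; on this read-out lower numbers stand for a weaker effect and higher numbers for a stronger effect at the one concentration tested.

Compound 2 has the lowest of the two numbers; its nearest neighbour is compound 1 a number 5.5 percentage points lower from compound 1 to compound 2 (within the scatter). Compound 3 `C[Si](C)(c1ccc(O)cc1)c1ccc(O)cc1` differs from compound 2 by hydrogen in place of sulfamoyl on an oxygen on an aromatic ring. Among the measured compounds shown here, the only measured step that bears on this, a number 5.5 percentage points lower from compound 1 to compound 2 (within the scatter), removed one of two sulfamoyl groups and stayed within the scatter. Compound 3, however, keeps no sulfamoyl group at all, a change the measured step does not cover, so the expected step is uncertain and estimated as a sizeable fall, a number 56.4 percentage points lower from compound 2 to compound 3 (beyond the scatter). Compound 3 is therefore estimated at 20%, ranging from 0% to 60%.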

Compound 3, a percentage reported as inhibition, at one concentration (the size of the read-out at that concentration, not a potency): < 10%
Compound 3: only a limit was reported; the forecaster's own chance of this, stated with the estimate: 0%; middle value at least 10 percentage points from the limit.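

In this assay, the swap of sulfamoyl for hydrogen that gave a number 5.5 percentage points lower from compound 1 to compound 2 (within the scatter) while a second sulfamoyl group remained now gives a number at least 66.4 percentage points lower from compound 2 to compound 3 (beyond the scatter). Among these three compounds, then, the same change matters greatly when it removes the last sulfamoyl group, and one such group is enough to keep most of the read-out. Compound 3 is reported only as a limit: the limit of < 10% in this assay, at which 1 of the 3 values shown sits.

The compounds shown leave open whether a different group on that oxygen, such as a methyl ether or an acetyl ester, could replace sulfamoyl. They also leave open how an amine or a carboxylic acid at this place would behave.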